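Cytotoxicity limits across a small series

A few compounds are considered here, and "the series" means these few. Any claim that something is new, unique, unknown or untested is made for them only; others in the source may bear on it.

The series is examined in an ADME assay on RD cells (Homo sapiens) for cytotoxicity; a lower number here means that less compound is tolerated, a higher number that more compound is tolerated. Compound 1 `O=C1Nc2ccccc2/C1=N/NC(=S)Nc1ccc(Cl)cc1` gives in this assay only a limit, > 25000 nM. Compound 2 `O=C1/C(=N\NC(=S)Nc2ccccc2)c2ccccc2N1c1ccccc1` likewise reaches only the limit of this assay, > 25000 nM. Compound 3 `COc1ccccc1NC(=S)N/N=C1\C(=O)Nc2ccccc21` also stops at the limit, > 25000 nM. So compound 1 stands where every measured member stands, at the limit of > 25000 nM in this assay, at which 3 of the 3 values shown sit; no number separates any two of them, and no ordering can be read from these three values.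

Among the measured compounds shown here, no measured pair differs in one place, so no measured step is available. Compound 4 `O=C1Nc2ccccc2/C1=N/NC(=S)Nc1cccc(Cl)c1` has not been measured in this assay. It differs from compound 1 by 3-chlorophenyl in place of 4-chlorophenyl on an amide-type nitrogen; the two compounds have the same atoms, joined differently.

For this change no step beyond the usual scatter is expected in this assay in either direction, because the measured members all sit at the limit of > 25000 nM in this assay, at which 3 of the 3 values shown sit. The step is estimated as a step that the limit leaves unreadable from compound 1 to compound 4. Compound 4 is expected to come out near 40000 nM, within 20000 nM to 100000 nM, and most probably the assay will again report only a limit for it rather than a number.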

Compound 4, half-maximal cytotoxic concentration: > 25000 nM
Compound 4: only a limit was reported (the forecaster's own chance of this, stated with the estimate: 85%); the middle value lies beyond the limit too.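

No step can be read between compound 1 and compound 4 in this assay, as both values are limits: the limit of > 25000 nM in this assay, at which 4 of the 4 values shown sit.

The compounds shown leave open whether 3-chlorophenyl in place of 4-chlorophenyl on an amide-type nitrogen makes any difference in this assay, and whether any numerical value separates the members of the series.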